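This account rests on a few compounds, and the source may have more. Where it says the series, first, only, none or still open, it means among the compounds named here.

In an ADME assay on Vero cells (Chlorocebus sabaeus) for cytotoxicity, read by MTT assay, with a stated time of 72 h (a higher number here means that more compound is tolerated, a lower number that less compound is tolerated), compound 3 `Cc1ccc(CNN2CCN(c3nc(=O)c4cc(C(F)(F)F)cc([N+](=O)[O-])c4s3)CC2)cc1` gives > 64 ug/mL as a limit and not a number. Compound 1 `CC(C)CN(CC(C)C)N1CCN(c2nc(=O)c3cc(C(F)(F)F)cc([N+](=O)[O-])c3s2)CC1` gives > 64 ug/mL as a limit too. Compound 2 `O=c1nc(N2CCN(NCc3ccc(C(F)(F)F)cc3)CC2)sc2c([N+](=O)[O-])cc(C(F)(F)F)cc12` gives > 64 ug/mL as a limit too. Compound 4 `O=c1nc(N2CCN(Nc3ccc(C(F)(F)F)cc3)CC2)sc2c([N+](=O)[O-])cc(C(F)(F)F)cc12` is still unmeasured and carries the change 4-(trifluoromethyl)phenyl in place of 4-methylbenzyl on an amine nitrogen in which 4-(trifluoromethyl)phenyl stands in place of 4-methylbenzyl on an amine nitrogen. Within the data shown here, two measured steps bear on it, namely a step that the two limits leave unreadable from compound 1 to compound 3 and a step that the two limits leave unreadable from compound 2 to compound 3 and neither gives a size to carry over. With all three measured compounds at the limit of > 64 ug/mL in this assay, at which 3 of the 3 values shown sit, no step beyond the scatter is expected in this assay in either direction. The expected step is a number no higher from compound 3 to compound 4 (the limit leaves the size open) and it remains an estimate. For compound 4 the estimate is 64 ug/mL with an expected range from 32 ug/mL to 128 ug/mL as its upper end.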

Compound 4, half-maximal cytotoxic concentration: > 64 ug/mL
Compound 4: no number, only a limit; the forecaster's own chance of this, stated with the estimate: 80%; the middle value lies on the limit itself.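

In this assay compound 4 gives > 64 ug/mL, a limit and not a number. Its steps from compound 1, compound 2 and compound 3 cannot be read. The compounds shown leave open at what concentration any of these four becomes cytotoxic.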